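Moving the Fluorine on a Fluoromethoxyphenyl Group

The source may hold more compounds than are shown below. What is called first, only, known or untested is meant among the compounds shown, and "the series" means these compounds.

Compound 3 `COc1cc(F)cc(-c2ccc(C(=O)N(Cc3cccc(OCCCCCC(=O)O)c3)C(C)C)cc2)c1` carries a 3-fluoro-5-methoxyphenyl group on an aromatic carbon of a shared core. In an ADME assay on Raji cells (Homo sapiens) for cytotoxicity, read by CellTiter-Glo and resazurin assay, with a stated time of 72 h (on this read-out higher numbers stand for an effect only at larger amounts of compound and lower numbers for an effect already at smaller amounts), compound 3 gives no number, only a limit of > 26000 nM. Compound 1 `CC(C)N(Cc1cccc(OCCCCCC(=O)O)c1)C(=O)c1ccc(-c2ccoc2)cc1` bears a furan-3-yl group at the same place; in this assay compound 1 likewise reaches only the limit > 26000 nM. Compound 2 `COc1cc(OC)cc(-c2ccc(C(=O)N(Cc3cccc(OCCCCCC(=O)O)c3)C(C)C)cc2)c1` carries a 3,5-dimethoxyphenyl group, and in this assay compound 2 also stops at the limit > 26000 nM. So far every value sits at the limit of > 26000 nM in this assay, at which 3 of the 3 values shown sit, and the steps a step that the two limits leave unreadable from compound 1 to compound 2, a step that the two limits leave unreadable from compound 1 to compound 3 and a step that the two limits leave unreadable from compound 2 to compound 3 cannot be sized.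

Compound 4 `COc1ccc(F)c(-c2ccc(C(=O)N(Cc3cccc(OCCCCCC(=O)O)c3)C(C)C)cc2)c1` differs from compound 3 by 2-fluoro-5-methoxyphenyl in place of 3-fluoro-5-methoxyphenyl on an aromatic carbon. Because the three measured compounds all sit at the limit of > 26000 nM in this assay, at which 3 of the 3 values shown sit, a readable step is not expected; the step from compound 3 to compound 4 is estimated as a step that the limit leaves unreadable from compound 3 to compound 4. Compound 4 is therefore expected at 30000 nM in this assay, within a range of 15000 nM to 80000 nM.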

Compound 4, half-maximal effective concentration: > 26000 nM
Compound 4 gave a limit, no number (the forecaster's own chance of this, stated with the estimate: 85%); the middle value is on the limit's open side.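

In this assay compound 4 gives > 26000 nM which is a limit and not a number, so its steps from compound 1, compound 2 and compound 3 cannot be read. The compounds shown leave open at what concentration any of them would affect these cells, with every value at one limit: the limit of > 26000 nM in this assay, at which 4 of the 4 values shown sit.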